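Vero cytotoxicity limits across the chalcone amide series

This account rests on a few compounds, and the source may have more. Where it says the series, first, only, none or still open, it means among the compounds named here.

Compound 1 `COC(=O)c1cc(-c2cccc(NC(=O)c3ccc(/C=C/C(=O)c4ccc(F)cc4)cc3)c2)on1`, compound 2 `COC(=O)c1cc(-c2cccc(NC(=O)c3ccc(/C=C/C(=O)c4ccc(Br)cc4)cc3)c2)on1` and compound 3 `COC(=O)c1cc(-c2cccc(NC(=O)c3ccc(/C=C/C(=O)c4ccc(C)c(F)c4)cc3)c2)on1` share one core and differ only in the group on the carbonyl carbon. In an ADME assay on Vero cells (Chlorocebus sabaeus) for cytotoxicity, read by MTT assay, with a stated time of 72 h (on this read-out lower numbers stand for higher toxicity in this test and higher numbers for lower toxicity in this test), compound 1 reaches only the limit > 20 ug/mL. In this assay compound 2 likewise stops at the limit > 20 ug/mL. Compound 3 stops at the limit > 50 ug/mL in this assay, so compound 3 stands among values that are all limits and not numbers. The steps a step that the two limits leave unreadable from compound 1 to compound 2, a step that the two limits leave unreadable from compound 1 to compound 3 and a step that the two limits leave unreadable from compound 2 to compound 3 therefore carry no readable size, as the limit of > 20 ug/mL in this assay, at which 2 of the 3 values shown sit, and the limit of > 50 ug/mL in this assay, at which 1 of the 3 values shown sits, show. Compound 4 `COC(=O)c1cc(-c2cccc(NC(=O)c3ccc(/C=C/C(=O)c4cccc(OC)c4)cc3)c2)on1` differs from compound 3 as follows: 3-methoxyphenyl in place of 3-fluoro-4-methylphenyl on a carbonyl carbon. Among the compounds with values here, no measured step reads directly on this change; the only bearing of the three measured steps is that none of them revealed toxicity within the tested window. No step beyond the scatter is therefore expected in this assay, and a number no higher from compound 3 to compound 4 (the limit leaves the size open) is the estimated step. Compound 4 is expected at 50 ug/mL, with a range from 20 ug/mL to 120 ug/mL, and most likely again reported as a limit.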

Compound 4, half-maximal cytotoxic concentration: > 100 ug/mL
Compound 4 gave a limit, no number (the forecaster's own chance of this, stated with the estimate: 75%); at least 2.0-fold (0.30 log units) between middle value and limit.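

In this assay compound 4 gives > 100 ug/mL, a limit and not a number, so its steps to compound 1, compound 2 and compound 3 cannot be read. The compounds shown leave open whether the groups on the carbonyl carbon differ in cytotoxicity at all.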